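This account rests on a few compounds, and the source may have more. Where it says the series, first, only, none or still open, it means among the compounds named here.

Measured in an ADME assay (liver) for metabolic stability, with Liver microsome (Homo sapiens) as the target, read by LC-MS, using microsomes and NADPH, with a stated time of 5 min, at 37 degrees C; on this read-out lower numbers stand for slow clearance and higher numbers for fast clearance:

- Compound 1 `CCn1c([C@@H](C)NS(=O)(=O)c2ccc(F)cc2)nc2ccc(C(F)(F)F)cc21`: 26 mL.min-1.g-1
- Compound 2 `CCn1c([C@@H](C)NS(=O)(=O)c2ccc(CC(C)C)cc2)nc2ccc(C(F)(F)F)cc21`: > 100 mL.min-1.g-1 (a limit)
- Compound 3 `CCCn1cc(S(=O)(=O)N[C@H](C)c2nc3ccc(C(F)(F)F)cc3n2CC)c(C)n1`: > 100 mL.min-1.g-1 (a limit)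

Compound 3 gives only a limit, > 100 mL.min-1.g-1, and not a number. The same limit applies to compound 2, so the three compounds include (the limit of > 100 mL.min-1.g-1 in this assay, at which 2 of the 3 values shown sit). Compound 4 `CCn1c([C@@H](C)NS(=O)(=O)c2cnc(NC(C)=O)s2)nc2ccc(C(F)(F)F)cc21` has not yet been measured. It differs from compound 3 on the sulfonyl sulfur: a group of 9 heavy atoms (5 carbon, 2 nitrogen, 1 oxygen, 1 sulfur; one five-membered aromatic ring with 2 hetero atoms) in place of a group of 9 heavy atoms (7 carbon, 2 nitrogen; one five-membered aromatic ring with 2 hetero atoms), on a sulfonyl sulfur. Among the compounds with values here, the entering group, 2-acetamido-1,3-thiazol-5-yl, appears in no measured compound, so no step shows its effect directly.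

Within the data shown here, three measured steps bear on this change. Two are readable only as minimum sizes, both beyond the scatter: an at least 3.8-fold higher number from compound 1 to compound 2 (0.58 log units; beyond the scatter) and an at least 3.8-fold higher number from compound 1 to compound 3 (0.58 log units; beyond the scatter). The third is a step that the two limits leave unreadable from compound 2 to compound 3. Together they show that this assay can respond strongly to changes in this part of the structure, though not which way a new group will push it. Among the measured compounds shown here, the only actual number comes from compound 1, at 26 mL.min-1.g-1, so the expectation leans towards that value and stays wide. A lower number than the limit is expected, by a modest step: an at least 3.3-fold lower number from compound 3 to compound 4 (0.52 log units; beyond the scatter). For compound 4 the estimated value is 30 mL.min-1.g-1, with an expected range from 10 mL.min-1.g-1 to 100 mL.min-1.g-1.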

Compound 4, intrinsic clearance in microsomes: 15 mL.min-1.g-1
For compound 4 the middle estimate is 2.0-fold (0.30 log units) above the measured one; the measured number falls inside the stated range.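

In this assay, 2-acetamido-1,3-thiazol-5-yl on the sulfonyl sulfur gives a measured number, which shows that a five-membered aromatic ring at this place does not have to end at the limit of compound 3, with an at least 6.6-fold lower number from compound 3 to compound 4 (0.82 log units; beyond the scatter) as the change. That step and an at least 6.6-fold lower number from compound 2 to compound 4 (0.82 log units; beyond the scatter) give only minimum sizes, because the starting compound of each sits at a limit and not at a number: the limit of > 100 mL.min-1.g-1 in this assay, at which 2 of the 4 values shown sit. Against the 4-fluorophenyl group, the result is a 1.7-fold lower number from compound 1 to compound 4 (0.24 log units; within the scatter) and so gives no order between the two, which shows that two quite different rings on the sulfonyl sulfur can share this low end of the read-out.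

As far as these compounds go, whether the change comes from the 1,3-thiazole ring or from the acetamido group stays open, and a 2-amino-1,3-thiazol-5-yl group or an unsubstituted 1,3-thiazol-5-yl group would help to separate the two. From the compounds shown here alone, it also stays open how a chain shorter than isobutyl, such as methyl or ethyl, would behave on the aromatic ring attached to the sulfonyl sulfur.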